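This account rests on a few compounds, and the source may have more. Where it says the series, first, only, none or still open, it means among the compounds named here.

The measured compounds:
Compound 1 `O=C(/C=C\c1ccccc1)N1N=C(c2ccncc2)OC1c1c[nH]c2ccccc12`: in an ADME assay on HeLa cells (Homo sapiens) for cytotoxicity, read by MTT assay, with a stated time of 72 h (a higher number here means a weaker inhibitor of growth, a lower number a stronger inhibitor of growth), compound 1 gives only a limit, > 30 ug/mL.
Compound 2 `O=C(/C=C\c1cccc(F)c1)N1N=C(c2ccncc2)OC1c1c[nH]c2ccccc12`: in this assay compound 2 likewise gives only a limit, > 30 ug/mL.

Compound 2 therefore stands at the edge of what this assay can read, not at a number, and the same holds for (the limit of > 30 ug/mL in this assay, at which 2 of the 2 values shown sit). Going by the values given here, the single measured step, a step that the two limits leave unreadable from compound 1 to compound 2, cannot be sized, since both of its ends are limits.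

Compound 3 `O=C(/C=C\c1ccccc1Cl)N1N=C(c2ccncc2)OC1c1c[nH]c2ccccc12` differs from compound 2 by 2-chlorophenyl in place of 3-fluorophenyl on a double-bonded chain carbon bound to a double-bonded chain carbon. Among the compounds with values here, no measured step bears directly on this change; the nearest comparison, a step that the two limits leave unreadable from compound 1 to compound 2, reports no size at all, so there is no measured basis for expecting a shift in either direction in this assay.

On that footing, compound 3 is expected to sit where compound 2 sits, with the reading again most likely a limit. The expected step that the limit leaves unreadable from compound 2 to compound 3 is thus none beyond the scatter. Compound 3 is estimated at 45 ug/mL in this assay, with a range from 15 ug/mL to 120 ug/mL.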

Compound 3, concentration for 50% growth inhibition: > 30 ug/mL
Compound 3 ended at the assay's limit (the forecaster's own chance of this, stated with the estimate: 80%); the middle value is on the limit's open side.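

No step among compound 1, compound 2 and compound 3 can be read, since each of the three ends at a limit and not at a number: the limit of > 30 ug/mL in this assay, at which 3 of the 3 values shown sit.

The compounds shown leave open whether compound 1, compound 2 and compound 3 differ at all in this assay; none of them gives a number there.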